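Compound 1 to compound 4: working notes on one swap

This account rests on a few compounds, and the source may have more. Where it says the series, first, only, none or still open, it means among the compounds named here.

Measured so far:
- compound 1 `C[Si](C)(C)Cn1nnc2c(C(N)=O)ncn2c1=O`: 28400 nM
- compound 2 `COc1ccc(Cn2nnc3c(C(N)=O)ncn3c2=O)c(OC)c1`: > 50000 nM (a limit)
- compound 3 `COc1ccc(Cn2nnc3c(C(N)=O)ncn3c2=O)cc1OC`: > 50000 nM (a limit)

Going by the values given here, in a functional assay on SNB-19 cells (Homo sapiens) for inhibition, read by MTT assay, with a stated time of 7 days (a lower number here means a stronger inhibitor of growth, a higher number a weaker inhibitor of growth), compound 1 gives 28400 nM, the only actual number in the set. The other two entries stand at the limit of > 50000 nM in this assay, at which 2 of the 3 values shown sit.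

Compound 4 `NC(=O)c1ncn2c(=O)n(Cc3cccs3)nnc12` has not yet been measured. The change from compound 1 is a group of 5 heavy atoms (4 carbon, 1 sulfur; one five-membered aromatic ring with 1 hetero atom) in place of a group of 4 heavy atoms (3 carbon, 1 silicon; no ring), on a saturated chain carbon bound to an aromatic nitrogen; thiophen-2-yl enters on a saturated chain carbon bound to an aromatic nitrogen. Among the compounds with values here, no measured step exists to scale this change.

Compound 2 also carries an aromatic ring on that chain carbon, and its value is a limit, > 50000 nM. Compound 3 does too, and its value is likewise a limit, > 50000 nM. On that basis, a step toward weaker inhibition of growth in this assay is expected, though none beyond the scatter. The expected change is a 1.4-fold higher number from compound 1 to compound 4 (0.15 log units; within the scatter). For compound 4 the estimated value is 40000 nM, with an expected range of 18000 nM to 90000 nM.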

Compound 4, concentration for 50% growth inhibition: > 50000 nM
Compound 4: no number, only a limit; the forecaster's own chance of this, stated with the estimate: 50%; middle value at least 1.2-fold (0.09 log units) from the limit.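

In this assay compound 4 gives > 50000 nM, which is a limit and not a number. Going by these compounds alone, this is the first one-place step at this position, and replacing the silicon-bearing group with thiophen-2-yl on a saturated chain carbon bound to an aromatic nitrogen gives an at least 1.7-fold higher number from compound 1 to compound 4 (0.24 log units; that floor lies within the scatter), so only a floor is fixed and it does not clear the scatter. Within the data shown here, a five-membered aromatic ring now joins the aromatic groups of compound 2 and compound 3 at the same ceiling, leaving compound 1 as the only compound with a number: the limit of > 50000 nM in this assay, at which 3 of the 4 values shown sit.

From the compounds shown here alone, the true size of the step remains unknown, and no order can be drawn among compound 2, compound 3 and compound 4. Also open, going by these compounds, is whether an amine, a carboxylic acid or a longer alkyl chain at this place would give a number at all.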